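Fluoro for Methoxy: Expected Cytotoxicity of Compound 3

The compounds below may be only part of what the source reports. "The series", "measured", "known", "first", "only" and "open" are said of these compounds alone.

Measured compounds:
compound 1 `O=C(Nc1ccc(Oc2ccnc3[nH]ccc23)c(F)c1)c1ccc(-c2ccccc2)cn1`: 760 nM
compound 2 `COc1ccc(-c2ccc(C(=O)Nc3ccc(Oc4ccnc5[nH]ccc45)c(F)c3)nc2)cc1`: 650 nM

In a functional assay on PC-3 cells (Homo sapiens) for cytotoxicity, read by MTT assay, with a stated time of 72 h (a lower number here means a stronger inhibitor, a higher number a weaker inhibitor), compound 1 gives 760 nM, while compound 2 gives 650 nM. The two differ at a single aromatic carbon, and the result of that change is a 1.2-fold lower number from compound 1 to compound 2 (0.07 log units; within the scatter). Compound 2 thus holds the lower of the two numbers, but its gap to compound 1 lies within the scatter, so neither compound can be called the stronger inhibitor on this evidence.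

Compound 3 `O=C(Nc1ccc(Oc2ccnc3[nH]ccc23)c(F)c1)c1ccc(-c2ccc(F)cc2)cn1` has not yet been measured. It differs from compound 2 in that (fluoro in place of methoxy on an aromatic carbon). Among the compounds with values here, the only measured step that bears on this position is the one from compound 1 to compound 2, and since placing a methoxy at this carbon moved the number by no more than the scatter, a fluoro at the same carbon is expected to leave this assay similarly unmoved, with no step beyond the scatter in either direction. The estimate for compound 3 is therefore 700 nM, with a range from 300 nM to 1600 nM. That corresponds to an expected 1.1-fold higher number from compound 2 to compound 3 (0.03 log units; within the scatter).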

Compound 3, half-maximal inhibitory concentration: 13400 nM
Estimate against measurement, compound 3: 19-fold (1.28 log units) below; measured number above the stated range.
By their numbers in this assay, from the lowest: compounds 2 and 1 (each within the scatter of the next); then compound 3.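

The aromatic carbon para to a large group is not indifferent in this assay, as the earlier pair alone had suggested: fluoro in place of methoxy gives a 21-fold higher number from compound 2 to compound 3 (1.31 log units; beyond the scatter), and fluoro in place of hydrogen gives an 18-fold higher number from compound 1 to compound 3 (1.25 log units; beyond the scatter), whereas methoxy in place of hydrogen had given only a 1.2-fold lower number from compound 1 to compound 2 (0.07 log units; within the scatter). Heavy-atom count does not sort these three compounds, since hydrogen and methoxy, the groups with the fewest and the most heavy atoms, give numbers within the scatter of each other, while the 4-fluorophenyl of compound 3 alone stands apart as the weakest inhibitor of the set. No measurement here bears on what lies behind this large step.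

Going by these compounds, whether the step belongs to fluoro alone or would also appear with chloro or bromo at this carbon stays open, as does how an amine or a hydroxyl there would read. The compounds shown also leave open whether fluoro on another carbon of this ring would give a similar number.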